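A few compounds are considered here, and "the series" means these few. Any claim that something is new, unique, unknown or untested is made for them only; others in the source may bear on it.

Of the compounds shown here, three have been tested in a functional assay on A549 cells (Homo sapiens) for cytotoxicity, read by MTT assay, with a stated time of 6 days; on this read-out higher numbers stand for an effect only at larger amounts of compound and lower numbers for an effect already at smaller amounts. Compound 1 `COC(=O)c1c(-c2cc(OC)cc(OC)c2)oc2ccccc2c1=O` gives only a limit of the assay, > 25 ug/mL, and not a true number. Compound 2 `COC(=O)c1c(-c2ccc([N+](=O)[O-])cc2)oc2cc(OC)ccc2c1=O` likewise gives only a limit, > 25 ug/mL. Going by the values given here, compound 3 `O=c1cc(-c2ccc([N+](=O)[O-])cc2)oc2ccc(O)cc12` gives 5.07 ug/mL, the only true number among the three.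

Compound 4 `Nc1ccc(-c2cc(=O)c3cc(O)ccc3o2)cc1` has not yet been measured. It keeps the core of compound 3 and changes a single group: amino in place of nitro on an aromatic carbon. Thus compound 4 carries amino where compound 3 carries nitro, para to a large group. Among the compounds with values here, no pair of measured compounds differs in just one place, so the data offer no measured step as a guide to size or direction in this assay. Within the data shown here, the only anchor is compound 3 at 5.07 ug/mL, so no shift beyond the scatter is expected. The expected step, a 1.2-fold higher number from compound 3 to compound 4 (0.07 log units; within the scatter), is therefore an estimate of little change. For compound 4 the estimated value is 6 ug/mL, with an expected range of 2 ug/mL to 20 ug/mL.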

Compound 4, concentration for half-maximal effect: 2.72 ug/mL
The estimate for compound 4 lay 2.2-fold (0.34 log units) above the measured number, within the range that was stated.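

Going by these compounds alone, this is the first step in the set that changes one place only: amino in place of nitro on an aromatic carbon, para to a large group. In this assay, the step is a 1.9-fold lower number from compound 3 to compound 4 (0.27 log units; within the scatter), so the two compounds cannot be told apart, even though nitro and amino differ in their heavy atoms and hydrogen-bond donors. Nothing measured here bears on why this exchange leaves the read-out within the scatter.

On these data alone, it remains open whether other groups at this place, such as a carboxylic acid or an acetamide, would also stay within the scatter of compound 3. Within the data shown here, compound 1 and compound 2 each differ from compound 3 in more than one place, and no step to them can be read.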